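The compounds below may be only part of what the source reports. "The series", "measured", "known", "first", "only" and "open" are said of these compounds alone.

The measured compounds: compound 1 `COc1ccc(-c2nc(SC)n(C)c(=O)c2C#N)cc1`, compound 2 `COc1ccc(-c2nc(NN)n(C)c(=O)c2C#N)cc1` and compound 3 `CCOC(=O)c1cnn(-c2nc(-c3ccc(OC)cc3)c(C#N)c(=O)n2C)c1N`. In a functional assay, with a stated time of 150 min (on this read-out lower numbers stand for stronger inhibition and higher numbers for weaker inhibition), compound 1 gives 73 ug/mL, compound 2 gives 56 ug/mL and compound 3 gives 79 ug/mL. Compound 2 has the lowest of the three numbers, though both of the others lie within the scatter of it. Compound 4 `CN(C)c1ccc(-c2nc(NN)n(C)c(=O)c2C#N)cc1` differs from compound 2 in one place: dimethylamino in place of methoxy on an aromatic carbon. Among the measured compounds shown here, only one step between measured compounds is known, a 1.3-fold lower number from compound 1 to compound 2 (0.12 log units; within the scatter), and it alters the shared core rather than the group on the six-membered aromatic ring of carbon only, so it does not bear directly on this change. With nothing measured pointing either way, compound 4 is expected to move little: no change at the digits printed from compound 2 to compound 4 (within the scatter). The estimate for compound 4 in this assay is 56 ug/mL, within 25 ug/mL to 125 ug/mL.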

Compound 4, half-maximal inhibitory concentration: 69 ug/mL
The estimate for compound 4 lay 1.2-fold (0.09 log units) below the measured number, and the stated range covers the measured number.
By their numbers in this assay, from the lowest: compounds 2, 4, 1 and 3 (each within the scatter of the next).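

In this assay, dimethylamino in place of methoxy on an aromatic carbon para to a large group gives a 1.2-fold higher number from compound 2 to compound 4 (0.09 log units; within the scatter) and so leaves no difference that can be told from the scatter. This is the first step shown at this position, and with these two groups the read-out stays within the scatter. No available evidence explains this result.

The compounds shown leave open whether a carboxylic acid, a primary amine or a longer alkoxy chain at this place would shift the number beyond the scatter.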